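Swapping a Butyl Chain for a Piperazine Side Chain

This account rests on a few compounds, and the source may have more. Where it says the series, first, only, none or still open, it means among the compounds named here.

Measured in an ADME assay on L02 cells (Homo sapiens) for cytotoxicity, read by sulforhodamine B assay; on this read-out lower numbers stand for stronger inhibition and higher numbers for weaker inhibition:
- Compound 1 `CCCCN1C(=O)c2cccc3c2c(cc2c4ccccc4sc32)C1=O`: "not determined" (no result reported)
- Compound 2 `CCCCN1C(=O)c2cccc3c2c(cc2c4ccccc4oc32)C1=O`: > 100000 nM

Only compound 2 offers a reading to start from, and that reading is not an ordinary number. Compound 2 gives > 100000 nM, which is a limit of the assay. This is the limit of > 100000 nM in this assay, at which 1 of the 2 values shown sits, and compound 1 provides no result to compare with it.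

Compound 3 `O=C1c2cccc3c2c(cc2c4ccccc4oc32)C(=O)N1CN1CCNCC1` keeps the core of compound 2 and changes its side chain. It has piperazin-1-yl in place of propyl on a saturated chain carbon bound to an amide-type nitrogen in a ring. Cut one bond further out, the same difference reads butyl to (piperazin-1-yl)methyl.

Going by the values given here, no measured pair shows what a change of this kind does in this assay, so any forecast is loose. A moderate move toward stronger inhibition, beyond the usual scatter, is expected, although compound 3 could also report only a limit. The estimated change is an at least 2.5-fold lower number from compound 2 to compound 3 (0.39 log units; beyond the scatter). For compound 3, the expected value is 40000 nM, with an estimated range of 8000 nM to 100000 nM.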

Compound 3, half-maximal inhibitory concentration: 11900 nM
For compound 3 the middle estimate is 3.4-fold (0.53 log units) above the measured one; low and high end bracket the measured number.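

In this assay, replacing propyl with piperazin-1-yl on a saturated chain carbon bound to an amide-type nitrogen in a ring gives an at least 8.4-fold lower number from compound 2 to compound 3 (0.92 log units; beyond the scatter), so this change moves the read-out toward stronger inhibition by more than the usual scatter. Going by these compounds alone, with the core held constant, this position therefore affects the result, and compound 3 provides the first ordinary number in this short series, one that later changes at this position can be compared against. The true size of the step remains unknown, and the printed figure is only a minimum because the starting compound sits at the assay's limit: the limit of > 100000 nM in this assay, at which 1 of the 3 values shown sits.

The compounds shown cannot separate the contribution of the ring from that of its nitrogen atoms, so it remains open whether morpholine, piperidine or a simple dimethylamino group at the same place would give a similar shift. Also unresolved are how a longer chain between the ring nitrogen of the core and the piperazine would behave, and whether piperazin-1-yl would produce a comparable change on the core of compound 1.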